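Aryl amide variation on the shared core

The compounds below may be only part of what the source reports. "The series", "measured", "known", "first", "only" and "open" are said of these compounds alone.

Compound 1 `CC(=O)Nc1cc2c(C3CCN(C)CC3)c[nH]c2cn1` gives 39 nM in an assay for binding affinity to 5-hydroxytryptamine receptor 1D (Homo sapiens), read by radioligand binding; a lower number here means a stronger inhibitor, a higher number a weaker inhibitor. Compound 2 `CN1CCC(c2c[nH]c3ccc(NC(=O)c4cccc(F)c4)nc23)CC1` gives 690 nM in this assay, the higher of the two numbers, and the gap to compound 1 lies beyond the scatter. Compound 3 `CN1CCC(c2c[nH]c3ccc(NC(=O)c4ccc([N+](=O)[O-])cc4)nc23)CC1` differs from compound 2 by 4-nitrophenyl in place of 3-fluorophenyl on a carbonyl carbon. Going by the values given here, no measured pair shows what such an aryl exchange does on this core, so compound 3 is expected to stay near compound 2, with a step of a 1.0-fold higher number from compound 2 to compound 3 (0.01 log units; within the scatter) of no size beyond the scatter in either direction. For compound 3 the estimate is 700 nM, with a range of 250 nM to 2000 nM.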

Compound 3, inhibition constant: 340 nM
Estimate against measurement, compound 3: 2.1-fold (0.31 log units) above, within the range that was stated.
By their numbers in this assay, from the lowest: compound 1; then compound 3; then compound 2.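

In this assay the aryl group on a carbonyl carbon is not a silent place: 4-nitrophenyl in place of 3-fluorophenyl gives a 2.0-fold lower number from compound 2 to compound 3 (0.31 log units; beyond the scatter) and stands as a modest step. This single exchange alters both the substituent and its printed ring number, so neither can be credited alone. No measurement shown bears on the cause of the step. Still open, as far as these compounds go, is how 4-fluorophenyl or 3-nitrophenyl would compare with compound 2 and compound 3, which would separate the two changes. Also open, from the compounds shown here alone, is what an aminophenyl group would do here.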